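From Fluoro to Trifluoromethoxy on Compound 2

The source may report more compounds than this note shows. Statements on the series, on what has been measured and on what is new or still open speak of the compounds shown alone.

Among the measured compounds shown here, only two compounds have been measured so far. In an ADME assay on the whole organism (strain Sprague-Dawley) for pharmacokinetics, with Rattus norvegicus as the target, using cassette dosing (a lower number here means slower removal, a higher number faster removal of the compound), compound 1 `O=C1CCc2cc(NC(=O)C[C@]3(O)CC[C@@H](Cc4ccccc4)CC3)ccc2N1` gives 24.4 mL/min/kg in the same test where compound 2 `O[C@]1(Cc2cc(-c3cn[nH]c3)on2)CC[C@H](Cc2ccc(F)cc2)CC1` gives 30 mL/min/kg as its number. These two values lie within the usual scatter of each other, so compound 2 stands level with compound 1 even though their structures are quite different.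

Compound 3 `O[C@]1(Cc2cc(-c3cn[nH]c3)on2)CC[C@H](Cc2ccc(OC(F)(F)F)cc2)CC1` keeps all of compound 2 except for one group. It carries trifluoromethoxy in place of fluoro on an aromatic carbon, para to a large group, and trifluoromethoxy in place of fluoro on an aromatic carbon gives the count of atoms that leave and enter.

The two measured compounds differ in more than one place, and so neither shows what a single swap like this does. With no such evidence, no step beyond the scatter is expected in this assay for this change. The expected change is a 1.1-fold lower number from compound 2 to compound 3 (0.03 log units; within the scatter) and this remains only an estimate. For compound 3 the estimated clearance is 28 mL/min/kg with an expected range from 14 mL/min/kg to 52 mL/min/kg in this test.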

Compound 3, clearance: 6.2 mL/min/kg
Beside the measured number, compound 3's estimate is 4.5-fold (0.65 log units) above it; measured number outside the range, below it.
By their numbers in this assay, from the lowest: compound 3; then compounds 1 and 2 (each within the scatter of the next).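

In this assay, putting trifluoromethoxy in place of fluoro on an aromatic carbon, para to a large group, gives a 4.8-fold lower number from compound 2 to compound 3 (0.68 log units; beyond the scatter), and this is the only step shown between compounds that differ in one place. It shows that this position is not indifferent to what sits on it: with the rest of the molecule unchanged, one replaced group is enough to move the number beyond the usual scatter, something the earlier pair, with structures differing in more than one place, could not reveal. Nothing measured here explains the fall, so the step stands as an observation on these two compounds and not as a general rule about either group.

Still open, from the compounds shown here alone, is whether the size of this step is particular to trifluoromethoxy, or whether a chlorine atom, a methoxy group or a trifluoromethyl group on the same carbon would give a similar number. The compounds shown also leave open whether the same swap would have a similar effect on a different core, such as the core of compound 1.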